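Oxadiazoline series: 3-fluorophenyl replacing 2,6-dichlorophenyl

The source may hold more compounds than are shown below. What is called first, only, known or untested is meant among the compounds shown, and "the series" means these compounds.

Compound 1 `COc1cc(C2=NN(C(C)=O)C(c3c(Cl)cccc3Cl)O2)cc(OC)c1OC` is read in a functional assay on BGC-823 cells (Homo sapiens) for antiproliferative activity, read by MTT assay, tested at 1 uM (on this read-out higher numbers stand for a stronger effect at the one concentration tested and lower numbers for a weaker effect), where compound 1 gives -1.4%. Compound 2 `COc1cccc(/C=N/NC(=O)c2cc(OC)c(OC)c(OC)c2)c1OC`, built on a different core, gives -0.1% in this assay, a value within the scatter of that of compound 1, so the two are not separable. Compound 3 `COc1cc(C(=O)N/N=C/c2ccccc2F)cc(OC)c1OC`, also on another core, gives 51.6%, which lies beyond the scatter from compound 1; of the three numbers, only compound 3 shows a clear effect at the concentration tested.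

Compound 4 `COc1cc(C2=NN(C(C)=O)C(c3cccc(F)c3)O2)cc(OC)c1OC` keeps the core of compound 1 and differs in one place: 3-fluorophenyl in place of 2,6-dichlorophenyl on a saturated ring carbon. Among the compounds with values here, no measured pair isolates this change, and no compound that shares the core of compound 1 shows a clear effect, so the step from compound 1 to compound 4 is expected to be small, at most a modest rise, and may well stay within the scatter; the expected step is a number 11.4 percentage points higher from compound 1 to compound 4 (beyond the scatter). Compound 4 is accordingly estimated at 10%, within a range from -8% to 38%.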

Compound 4, a percentage reported as inhibition, at one concentration (the size of the read-out at that concentration, not a potency): 14.7%
Compound 4: middle estimate off by 4.7 percentage points, on the low side; low and high end bracket the measured number.
By their numbers in this assay, from the lowest: compounds 1 and 2 (each within the scatter of the next); then compound 4; then compound 3.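

In this assay the swap to 3-fluorophenyl gives a number 16.1 percentage points higher from compound 1 to compound 4 (beyond the scatter), so the aryl group on the saturated ring carbon does bear on the read-out. Within the data shown here, compound 4 is the first compound on the core of compound 1 to separate from compound 1 beyond the scatter, although the step is modest and rests on one concentration, which gives no potency. No available evidence accounts for the rise.

The change removes both chlorines and adds a fluorine at once, so the compounds shown cannot assign the step to any one of these edits. Also open, going by these compounds, is how the shared core responds to an unsubstituted phenyl, or to a phenyl carrying an amine or a carboxylic acid, at this position.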